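Pyrrolidine acyl cap of compound 2: urea variant

This account rests on a few compounds, and the source may have more. Where it says the series, first, only, none or still open, it means among the compounds named here.

Compound 1 `CC(C)(C)OC(=O)N1CCC[C@@H]1C(=O)N1CCC(NS(=O)(=O)c2cc(S(=O)(=O)c3ccccc3)ccc2C(F)(F)F)CC1` gives 120 nM in an assay on isolated protein for binding affinity to secreted frizzled-related protein 1 (Homo sapiens), read by fluorescence; on this read-out higher numbers stand for weaker inhibition and lower numbers for stronger inhibition. Compound 2 `CN(C)CC(=O)N1CCC[C@H]1C(=O)N1CCC(NS(=O)(=O)c2cc(S(=O)(=O)c3ccccc3)ccc2C(F)(F)F)CC1` gives 90 nM in this assay, and the step of a 1.3-fold lower number from compound 1 to compound 2 (0.12 log units; within the scatter) is within the scatter, so compound 2 and compound 1 stand level. Compound 3 `O=C([C@@H]1CCCN1C(=O)Nc1ccccc1)N1CCC(NS(=O)(=O)c2cc(S(=O)(=O)c3ccccc3)ccc2C(F)(F)F)CC1` carries the change (anilino in place of (dimethylamino)methyl on a carbonyl carbon), on the same carbonyl carbon that the step from compound 1 to compound 2 altered. For the measured compounds named here, that one step, within the scatter, is the only comparison bearing on it, so no step beyond the scatter is expected for compound 3 in this assay. Compound 3 is estimated at 100 nM, range 40 nM to 300 nM, a step of a 1.1-fold higher number from compound 2 to compound 3 (0.05 log units; within the scatter) that is expected to stay within the scatter.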

Compound 3, half-maximal inhibitory concentration: 20 nM
For compound 3 the middle estimate is 5.0-fold (0.70 log units) above the measured one; measured number below the stated range.
By their numbers in this assay, from the lowest: compound 3; then compounds 2 and 1 (each within the scatter of the next).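

Anilino in place of (dimethylamino)methyl on this carbonyl carbon gives a 4.5-fold lower number from compound 2 to compound 3 (0.65 log units; beyond the scatter) in this assay and is the first step at this position to lie beyond the scatter. The change brings in a six-membered aromatic ring and a hydrogen-bond donor together, and these compounds do not separate the two. No measured evidence bears on the cause of this step. Open, going by these compounds, is which of the two carries the step: N-methylanilino keeps the ring without the amide hydrogen, while cyclohexylamino keeps that hydrogen without the aromatic ring.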